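This account rests on a few compounds, and the source may have more. Where it says the series, first, only, none or still open, it means among the compounds named here.

Working notes on the pyrrolidine amide series.

Three compounds carry a measured number in an assay on HEK293 cells for inhibition of N-acylethanolamine-hydrolyzing acid amidase (Rattus norvegicus), read by LC-MS, with a stated time of 30 min; a lower number here means a stronger inhibitor, a higher number a weaker inhibitor. Compound 1 `Cc1cccc(CCCCCCC(=O)N2CCCC2)c1` gives 8300 nM. Compound 2 `Cc1ccc(CCCCCCC(=O)N2CCCC2)cc1` gives 9600 nM. Compound 3 `O=C(CCCCCCc1cccc(F)c1)N1CCCC1` gives 7300 nM. Compound 1 and compound 2 share the same atoms joined differently; the difference between the two cores is not broken down here. All three numbers sit within the usual scatter of one another, so no order among them is claimed.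

One change has a measured precedent. From compound 1 to compound 3 the change is fluoro in place of methyl on an aromatic carbon and the step is a 1.1-fold lower number from compound 1 to compound 3 (0.06 log units; within the scatter). Compound 4 `O=C(CCCCCCc1ccc(F)cc1)N1CCCC1` is not yet measured; from compound 2 to compound 4 the change is fluoro in place of methyl on an aromatic carbon. This is the same kind of change, but the place differs: meta to a large group in the first pair, para to a large group in the second.

Given that the step from compound 1 to compound 3 stayed within the scatter, the step from compound 2 to compound 4 is expected to be about a 1.1-fold lower number from compound 2 to compound 4 (0.05 log units; within the scatter) in this assay. Compound 4 is therefore expected to give about 8500 nM, between 4500 nM and 16000 nM, resting on compound 2 at 9600 nM and the precedent a 1.1-fold lower number from compound 1 to compound 3 (0.06 log units; within the scatter).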

Compound 4, half-maximal inhibitory concentration: 8000 nM
Beside the measured number, compound 4's estimate is 1.1-fold (0.03 log units) above it; measured number inside the range.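

In this assay the new step is a 1.2-fold lower number from compound 2 to compound 4 (0.08 log units; within the scatter), and like the earlier step it lies within the scatter. Set side by side, the two steps of fluoro in place of methyl on an aromatic carbon do not differ: the same change on two cores in this assay, a 1.1-fold lower number (0.06 log units; within the scatter) from compound 1 to compound 3 and a 1.2-fold lower number (0.08 log units; within the scatter) from compound 2 to compound 4, 1.1-fold (0.02 log units) apart, within the scatter of two such steps. This shows that, on these two cores, the change carries across with no step beyond the scatter on either one, but it does not show that a larger step would carry over in the same way, and two pairs set no rule for the whole series.

On these data alone, all four compounds share the same chain and the same amide, so how this change behaves on a shorter or longer chain, or with a piperidine amide, remains open. Also open, as far as these compounds go, is whether a chloro or trifluoromethyl group on the aromatic ring would give a step beyond the scatter in this assay.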